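The compounds below may be only part of what the source reports. "The series", "measured", "known", "first", "only" and "open" are said of these compounds alone.

Series notes. In an assay on CHO-K1 cells for displacement of a labelled ligand from 5-hydroxytryptamine receptor 6 (Homo sapiens), read by scintillation counting, with a stated time of 3 h (a higher number here means a weaker inhibitor, a lower number a stronger inhibitor), compound 1 `O=C1CC(c2ccccc2)CN1c1ccc2c(N3CCNCC3)ccnc2c1` gives 55 nM, compound 2 `O=C1CCCN1c1cnc2c(N3CCNCC3)cccc2c1` gives 4900 nM, and compound 3 `O=C1OC(c2ccccc2F)CN1c1ccc2c(c1)CCNCC2` gives 15 nM. Among these three numbers compound 3 stands lowest; compound 1 is its nearest neighbour and compound 2 the furthest, both gaps lying beyond the scatter. Compound 4 `O=C1OC(c2cccc(Cl)c2)CN1c1ccc2c(c1)CCNCC2` differs from compound 3 in a single place: 3-chlorophenyl in place of 2-fluorophenyl on a saturated ring carbon. Among the measured compounds shown here, no pair of measured compounds isolates this change, so the size of the step rests on judgement alone. The move is expected to stay near the scatter in this assay, if anything drifting toward a slightly higher number. For compound 4 the estimate is 22 nM, with a range of 6 nM to 80 nM. The expected step from compound 3 to compound 4 is a 1.5-fold higher number from compound 3 to compound 4 (0.17 log units; within the scatter).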

Compound 4, inhibition constant: 10 nM
Compound 4: middle estimate off by 2.2-fold (0.34 log units), on the high side; measured number inside the range.
By their numbers in this assay, from the lowest: compounds 4 and 3 (each within the scatter of the next); then compound 1; then compound 2.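

In this assay, among the compounds shown here, the step at the saturated ring carbon next to the ring oxygen is a 1.5-fold lower number from compound 3 to compound 4 (0.18 log units; within the scatter) for 3-chlorophenyl in place of 2-fluorophenyl, the first step that can be read. This position therefore accepts either substituted phenyl without a change beyond the scatter, although the halogen and its place on the phenyl ring change together. Nothing measured on hand bears on the reason for this. Open, going by these compounds, is how 2-chlorophenyl or 3-fluorophenyl would read, which would separate those two changes. Also open, on these data alone, is whether this carbon would accept an unsubstituted phenyl, or a phenyl carrying an amine or a carboxylic acid.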